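Changing the amide group: from compound 2 to compound 3

The compounds below may be only part of what the source reports. "The series", "measured", "known", "first", "only" and "open" are said of these compounds alone.

Two compounds share one core and differ only in the group on an amide-type nitrogen. In a functional assay on HepG2 cells (Homo sapiens) for antiproliferative activity, read by MTT assay, with a stated time of 48 h (a higher number here means a weaker inhibitor, a lower number a stronger inhibitor), compound 1 `CCn1c(C(=O)NCCN(C)C)ccc1C(CC)(CC)c1ccc(OCCC(O)(CC)CC)c(C)c1` gives 240 nM, while compound 2 `CCn1c(C(=O)NC(C)C(=O)O)ccc1C(CC)(CC)c1ccc(OCCC(O)(CC)CC)c(C)c1` gives 1740 nM. Compound 2 therefore holds the higher of the two numbers, which makes it the weaker inhibitor of the pair. Compound 3 `CCn1c(C(=O)NC(CO)CCO)ccc1C(CC)(CC)c1ccc(OCCC(O)(CC)CC)c(C)c1` keeps the same core but carries 3-hydroxy-1-(hydroxymethyl)propyl in place of 1-carboxyethyl on the amide-type nitrogen: 3-hydroxy-1-(hydroxymethyl)propyl in place of 1-carboxyethyl on an amide-type nitrogen. For the measured compounds named here, only one measured step bears on this change, and it sits at the same place: a 7.3-fold higher number from compound 1 to compound 2 (0.86 log units; beyond the scatter). From the compounds shown here alone, this modest step shows that the group here can shift the number, but the new group itself is untested. With only compound 1 at 240 nM for comparison, a move toward a lower number, smaller than that step, seems the likelier outcome, though this expectation is uncertain. The expected change is a 2.3-fold lower number from compound 2 to compound 3 (0.37 log units; beyond the scatter). For compound 3, the estimated value is 750 nM, with an expected range of 220 nM to 2500 nM.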

Compound 3, half-maximal inhibitory concentration: 24800 nM
Compound 3: the middle estimate sits 33-fold (1.52 log units) below what was measured; measured number outside the range, above it.
By their numbers in this assay, from the lowest: compound 1; then compound 2; then compound 3.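

In this assay, for the compounds shown here, the group on the amide-type nitrogen proves to matter more than the first pair of compounds could show: replacing 1-carboxyethyl with 3-hydroxy-1-(hydroxymethyl)propyl gives a 14-fold higher number from compound 2 to compound 3 (1.15 log units; beyond the scatter), a move toward weaker inhibition. The full span seen at this one place reaches a 100-fold higher number from compound 1 to compound 3 (2.01 log units; beyond the scatter), so changing this group alone, with the shared core untouched, can separate these compounds widely, and 2-(dimethylamino)ethyl remains the group with the lowest number, its steps to both others lying beyond the scatter. No measurement is available that bears on the reason for this result.

The three compounds leave open whether the lower number of compound 1 goes with its dimethylamino end or with the rest of its chain, as the groups differ from one another in more than one feature at once. How a simple 2-hydroxyethyl group or a longer amine chain such as 3-(dimethylamino)propyl would behave on the same nitrogen remains an open question.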